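This account rests on a few compounds, and the source may have more. Where it says the series, first, only, none or still open, it means among the compounds named here.

Three compounds sharing one core have been run in a functional assay on A549 cells (Homo sapiens) for antiproliferative activity, read by MTT assay, with a stated time of 72 h; on this read-out lower numbers stand for stronger inhibition and higher numbers for weaker inhibition. Compound 1 `O=C(Nc1ccc(Oc2ccnc3[nH]ccc23)cc1)c1cc2cccnc2n(-c2ccc(Br)cc2)c1=O` gives 280 nM. Compound 2 `COc1ccc(-n2c(=O)c(C(=O)Nc3ccc(Oc4ccnc5[nH]ccc45)cc3)cc3cccnc32)cc1` gives 930 nM; the step of a 3.3-fold higher number from compound 1 to compound 2 (0.52 log units; beyond the scatter) corresponds to the change (methoxy in place of bromo on an aromatic carbon). Compound 3 `O=C(Nc1ccc(Oc2ccnc3[nH]ccc23)c(F)c1)c1cc2cccnc2n(-c2ccc(Br)cc2)c1=O` gives 210 nM; the step of a 1.3-fold lower number from compound 1 to compound 3 (0.12 log units; within the scatter) corresponds to the change (fluoro in place of hydrogen on an aromatic carbon), which is also how the core of compound 3 differs from the core of compound 1. Compound 4 `COc1ccc(-n2c(=O)c(C(=O)Nc3ccc(Oc4ccnc5[nH]ccc45)c(F)c3)cc3cccnc32)cc1` has not been measured. It differs from compound 3 by methoxy in place of bromo on an aromatic carbon, the same change as that made from compound 1 to compound 2, so the change appears twice in this set. For compound 4 in this assay the step is expected to be a 3.3-fold higher number from compound 3 to compound 4 (0.52 log units; beyond the scatter), resting on compound 1 and compound 2, whose step a 3.3-fold higher number from compound 1 to compound 2 (0.52 log units; beyond the scatter) went the same way on a core that differs only by the fluoro. Since the fluoro step a 1.3-fold lower number from compound 1 to compound 3 (0.12 log units; within the scatter) lies within the scatter, the methoxy step is expected to carry over in size. Compound 4 is therefore estimated at 700 nM, between 380 nM and 1500 nM.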

Compound 4, half-maximal inhibitory concentration: 610 nM
Estimate against measurement, compound 4: 1.1-fold (0.06 log units) above, within the range that was stated.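

In this assay, the change from 4-bromophenyl to 4-methoxyphenyl on the fluoro-bearing core gives a 2.9-fold higher number from compound 3 to compound 4 (0.46 log units; beyond the scatter), and this step agrees with the one on the core without the fluoro: the same change on two cores in this assay, a 3.3-fold higher number (0.52 log units; beyond the scatter) from compound 1 to compound 2 and a 2.9-fold higher number (0.46 log units; beyond the scatter) from compound 3 to compound 4, 1.1-fold (0.06 log units) apart, within the scatter of two such steps. The fluoro step, read on the methoxy pair as a 1.5-fold lower number from compound 2 to compound 4 (0.18 log units; within the scatter), also agrees across the two cores and stays within the scatter on both: the same change on two cores in this assay, a 1.3-fold lower number (0.12 log units; within the scatter) from compound 1 to compound 3 and a 1.5-fold lower number (0.18 log units; within the scatter) from compound 2 to compound 4, 1.1-fold (0.06 log units) apart, within the scatter of two such steps. In these four compounds, each change therefore carries over from one core to the other with no detectable dependence on the other change, but the two cores differ only by the fluoro, so this shows nothing about more distant cores or about the reason for the methoxy step.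

Going by these compounds, only bromo and methoxy appear at this place on the phenyl ring, so the outcome with an amine, a carboxylic acid or a longer alkoxy chain remains open. Also open, on these data alone, is whether a chloro or methyl group in place of the fluoro would leave the methoxy step the same.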